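The compounds below may be only part of what the source reports. "The series", "measured", "known", "first", "only" and "open" are said of these compounds alone.

Working notes on the deoxyribose-linked series.

Compound 1 `Nc1nccc2c1ncn2[C@H]1C[C@H](O)[C@@H](CO)O1` carries an amino group on the aromatic carbon of the fused core; in a functional assay (Homo sapiens) for inhibition of Nucleic Acid, tested at 100 uM (on this read-out lower numbers stand for less inhibition and higher numbers for more inhibition at the one concentration tested (going by the name of the read-out)), compound 1 gives 18%. Compound 2 `CN(C)c1nccc2c1ncn2[C@H]1C[C@H](O)[C@@H](CO)O1` carries a dimethylamino group in the same place, and in this assay compound 2 gives 0%. Within the data shown here, the one step measured so far, a number 18 percentage points lower from compound 1 to compound 2 (beyond the scatter), is the only comparison on this read-out, and it puts compound 2 at the lowest of the two numbers seen, with compound 1 the nearest point above it.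

Compound 3 `OC[C@H]1O[C@@H](n2cnc3c(Cl)nccc32)C[C@@H]1O` is the next member to be measured. The change from compound 2 is chloro in place of dimethylamino on an aromatic carbon. Among the measured compounds shown here, no measured step shows a chloro group at this position, so the expectation for compound 3 rests only on the two numbers already in hand, which both lie near the bottom of the scale and differ by the step from compound 1 to compound 2. For compound 3 a step of a number 8 percentage points higher from compound 2 to compound 3 (within the scatter) is estimated, which would leave it within the scatter of compound 2. Compound 3 is therefore expected to give about 8% in this assay, with a plausible range of -5% to 25%.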

Compound 3, a percentage reported as inhibition, at one concentration (the size of the read-out at that concentration, not a potency): 5%
The estimate for compound 3 lay 3 percentage points above the measured number; measured number inside the range.
By their numbers in this assay, from the lowest: compounds 2 and 3 (each within the scatter of the next); then compound 1.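

In this assay, the step of a number 5 percentage points higher from compound 2 to compound 3 (within the scatter) means that chloro and dimethylamino on this aromatic carbon, next to the ring nitrogen, are not told apart, although the group that leaves has 3 heavy atoms and 1 hydrogen-bond acceptor and the one that enters has 1 heavy atom and no hydrogen-bond acceptor. With a number 13 percentage points lower from compound 1 to compound 3 (beyond the scatter) alongside a number 18 percentage points lower from compound 1 to compound 2 (beyond the scatter) there are now two different replacements of the amino group, and both land beyond the scatter on the low side, so among these three compounds only the amino compound stands apart, and a single replacement no longer carries that reading. Nothing measured on these compounds offers an explanation for this.

From the compounds shown here alone, whether the amino group itself matters, or only the presence of a hydrogen on that nitrogen, stays open: a methylamino or a hydroxyl group at this position would separate those readings. Going by these compounds, all three numbers also come from one concentration and sit low on the scale, so how these compounds compare in potency remains unknown.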